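The compounds below may be only part of what the source reports. "The series", "measured", "known", "first", "only" and "open" are said of these compounds alone.

Two measured compounds set the scene. In an assay on brain for displacement of a labelled ligand from Adrenergic receptor alpha-1 (Rattus norvegicus) (a lower number here means a stronger inhibitor, a higher number a weaker inhibitor), compound 1 `COCCOC1CCN(c2nc(N)c3cc(OC)c(OC)cc3n2)CC1` gives 2.12 nM, and compound 2 `COc1cc2nc(N3CCC(OCC(C)O)CC3)nc(N)c2cc1OC` gives 3.52 nM. These two share a core and differ only in the chain hanging from an oxygen on a saturated carbon: a 1.7-fold higher number from compound 1 to compound 2 (0.22 log units; within the scatter). Compound 2 therefore carries the higher of the two numbers, but the gap to compound 1 lies within the scatter, so neither can be called the stronger inhibitor. Compound 3 `CCOCC(OC1CCN(c2nc(N)c3cc(OC)c(OC)cc3n2)CC1)c1ccccc1` has not yet been measured; it alters compound 2 at that same oxygen: 2-ethoxy-1-phenylethyl in place of 2-hydroxypropyl on an oxygen on a saturated carbon. Going by the values given here, only the step from compound 1 to compound 2 touches this position, and it stayed within the scatter, so the measured data offer little guidance for a far larger replacement. On that thin basis, compound 3 is expected to shift only modestly from compound 2, by a 1.3-fold higher number from compound 2 to compound 3 (0.11 log units; within the scatter), with wide uncertainty. Compound 3 is estimated at 4.5 nM, within a range from 1 nM to 25 nM.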

Compound 3, inhibition constant: 10 nM
Compound 3: the middle estimate sits 2.2-fold (0.35 log units) below what was measured, and the stated range covers the measured number.
By their numbers in this assay, from the lowest: compounds 1 and 2 (each within the scatter of the next); then compound 3.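

In this assay, the substituent on this oxygen now shows a shift beyond the scatter: 2-ethoxy-1-phenylethyl gives a 2.8-fold higher number from compound 2 to compound 3 (0.45 log units; beyond the scatter) and, measured against the 2-methoxyethyl chain, a 4.7-fold higher number from compound 1 to compound 3 (0.67 log units; beyond the scatter) in the same direction. The position is therefore not indifferent to what it carries, although the steps are modest and compound 3, with its 11 heavy atoms and six-membered aromatic ring, still gives 10 nM. No measured evidence here accounts for this shift.

The new group differs from the earlier chains in both its size and its aromatic ring, so these compounds cannot show which of the two matters. A simple benzyl group would separate the ring from the ethoxy-bearing chain, while an amine at the chain end would test a different kind of group at this position.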